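Replacing the triazole group of compound 3

The source may report more compounds than this note shows. Statements on the series, on what has been measured and on what is new or still open speak of the compounds shown alone.

Measured in a toxicity assay on L02 cells (Homo sapiens) for cytotoxicity, read by MTT assay, with a stated time of 72 h; a higher number here means a weaker inhibitor, a lower number a stronger inhibitor:
compound 1 `CN(C)CCCCCn1c2c(c3ccccc31)C(=O)c1c[n+]([O-])c3ccccc3c1C2=O`: 240 nM
compound 2 `O=C1c2c[n+]([O-])c3ccccc3c2C(=O)c2c1c1ccccc1n2CCCCn1ccnc1`: 150 nM
compound 3 `O=C1c2c[n+]([O-])c3ccccc3c2C(=O)c2c1c1ccccc1n2Cc1cn(CC(O)CO)nn1`: 1070 nM

Of these three, compound 3 gives the highest number in this assay, at 1070 nM. Compound 4 `O=C1c2c[n+]([O-])c3ccccc3c2C(=O)c2c1c1ccccc1n2CCN1CCCC1` has not yet been measured. It differs from compound 3 as follows: (pyrrolidin-1-yl)methyl in place of 1-(2,3-dihydroxypropyl)-1H-1,2,3-triazol-4-yl on a saturated chain carbon bound to an aromatic nitrogen. Cut one bond further out, the entering group reads 2-(pyrrolidin-1-yl)ethyl.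

Among the compounds with values here, two measured steps bear most directly on this change, as both arrive at the triazole group: a 4.5-fold higher number from compound 1 to compound 3 (0.65 log units; beyond the scatter) and a 7.1-fold higher number from compound 2 to compound 3 (0.85 log units; beyond the scatter). Each lies beyond the scatter. Exchanging one chain end for another without the triazole, a 1.6-fold lower number from compound 1 to compound 2 (0.20 log units; within the scatter), stays within it. Within the data shown here, no measured compound carries the 2-(pyrrolidin-1-yl)ethyl group, so the transfer is uncertain. Leaving the triazole group is nevertheless expected to reverse those two steps in size, towards a lower number. The expected step is a 4.3-fold lower number from compound 3 to compound 4 (0.63 log units; beyond the scatter). The estimate for compound 4 is 250 nM, with an expected range of 90 nM to 700 nM.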

Compound 4, half-maximal inhibitory concentration: 930 nM
Compound 4: the middle estimate sits 3.7-fold (0.57 log units) below what was measured; the whole stated range lies below it.
By their numbers in this assay, from the lowest: compounds 2 and 1 (each within the scatter of the next); then compounds 4 and 3 (each within the scatter of the next).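

In this assay, the change of end group gives a 1.2-fold lower number from compound 3 to compound 4 (0.06 log units; within the scatter) and so stays within the scatter, which shows that the high number of compound 3 is not tied to the 1-(2,3-dihydroxypropyl)-1H-1,2,3-triazol-4-yl group: a 2-(pyrrolidin-1-yl)ethyl chain with no triazole stands at the same level. The steps of a 6.2-fold higher number from compound 2 to compound 4 (0.79 log units; beyond the scatter) and a 3.9-fold higher number from compound 1 to compound 4 (0.59 log units; beyond the scatter) both lie beyond the scatter, so leaving the triazole does not by itself return the number to that of the two longer chains, although chain length and chain end change together in these steps. Nothing available here explains these steps.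

Whether the ethyl chain or the pyrrolidine ring accounts for the gap stays open. A 2-(dimethylamino)ethyl chain or a 5-(pyrrolidin-1-yl)pentyl chain on the shared core would separate the two.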